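The source may hold more compounds than are shown below. What is called first, only, known or untested is meant among the compounds shown, and "the series" means these compounds.

Measured compounds:
Compound 1 `O=C(NCCCOc1cccc(CN2CCCCC2)c1)Nc1ccccc1` gives 126 nM in an assay on isolated protein for inhibition of histamine H2 receptor (Cavia porcellus); a lower number here means tighter binding, a higher number weaker binding.
Compound 2 `Cc1ccc(NC(=O)NCCCOc2cccc(CN3CCCCC3)c2)cc1` gives 631 nM in this assay.

Going by the values given here, compound 1 holds the lower of the two numbers in this assay; its only neighbour is compound 2, reached by a 5.0-fold higher number from compound 1 to compound 2 (0.70 log units; beyond the scatter), a modest but real loss. Compound 3 `CC(C)(C)NC(=O)NCCCOc1cccc(CN2CCCCC2)c1` is not yet measured. It differs from compound 1 by tert-butyl in place of phenyl on an amide-type nitrogen, so the whole aromatic ring at this end is exchanged for a branched alkyl group on the amide-type nitrogen whose other neighbour is the carbonyl carbon. Among the compounds with values here, no measured step concerns this exchange; the step from compound 1 to compound 2 touches the same phenyl and shows that altering it weakens binding, which is the only indirect hint available. The expectation for compound 3 is therefore a step of a 2.5-fold higher number from compound 1 to compound 3 (0.40 log units; beyond the scatter), towards weaker binding, with wide uncertainty. Compound 3 is estimated at 320 nM, within a range from 60 nM to 1600 nM.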

Compound 3, dissociation constant: 2090 nM
Estimate against measurement, compound 3: 6.5-fold (0.81 log units) below; measured number outside the range, above it.
By their numbers in this assay, from the lowest: compound 1; then compound 2; then compound 3.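

In this assay, exchanging the whole aromatic ring on the amide-type nitrogen for tert-butyl proves far more costly than adding methyl to that ring, with a 17-fold higher number from compound 1 to compound 3 (1.22 log units; beyond the scatter) as a large loss. Even the 4-methylphenyl group, the poorer of the two aromatic groups, keeps tighter binding than tert-butyl, with a 3.3-fold higher number from compound 2 to compound 3 (0.52 log units; beyond the scatter) as a modest but real gap. So this position ranks phenyl first, 4-methylphenyl second and tert-butyl last, but no data at hand offer any reason for that order.

From the compounds shown here alone, whether the loss follows from removing the aromatic ring or from the branched shape of tert-butyl stays open, and cyclohexyl, n-butyl or benzyl on this nitrogen would help separate the two. Going by these compounds, it is also open whether a fluorine or methoxy group on the phenyl ring would weaken binding as methyl does.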